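Swapping piperidin-4-yl for 4-hydroxyphenyl at the assay limit

This account rests on a few compounds, and the source may have more. Where it says the series, first, only, none or still open, it means among the compounds named here.

Compound 1 `COc1ccc(-c2noc(C3CCCN3)n2)cc1OC1CCCC1`: > 1000000 nM (a limit)
Compound 2 `COc1ccc(-c2noc(C3CCNCC3)n2)cc1OC1CCCC1`: > 1000000 nM (a limit)
Compound 3 `COc1ccc(-c2noc(Cc3c[nH]c4ccccc34)n2)cc1OC1CCCC1`: > 1000000 nM (a limit)

In a functional assay on PC-3 cells (Homo sapiens) for antiproliferative activity, read by MTT assay, with a stated time of 24 h (a higher number here means a weaker inhibitor, a lower number a stronger inhibitor), compound 2 gives > 1000000 nM, which is a limit and not a number. Compound 1 gives > 1000000 nM, also a limit. Compound 3 gives > 1000000 nM, again a limit. All three measurements therefore share one edge, namely (the limit of > 1000000 nM in this assay, at which 3 of the 3 values shown sit), and compound 2 cannot be ranked against the other two.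

Compound 4 `COc1ccc(-c2noc(-c3ccc(O)cc3)n2)cc1OC1CCCC1` has not yet been measured. It carries 4-hydroxyphenyl in place of piperidin-4-yl on an aromatic carbon, and the counted difference is 4-hydroxyphenyl in place of piperidin-4-yl on an aromatic carbon. Among the compounds with values here, the one measured step at this place on the shared core is a step that the two limits leave unreadable from compound 1 to compound 2, so it offers no size to carry over. With no readable step, any expectation stays loose. The likeliest outcome is that compound 4 also sits at the limit, and any number that does appear would have to lie on the stronger side. The expected change in this assay is an at least 2.5-fold lower number from compound 2 to compound 4 (0.39 log units; beyond the scatter), and its size is only a rough estimate. Compound 4 is estimated at 400000 nM, with an expected range from 40000 nM to 1000000 nM.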

Compound 4, half-maximal inhibitory concentration: 162000 nM
Compound 4: the middle estimate sits 2.5-fold (0.39 log units) above what was measured; measured number inside the range.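

Within the data shown here, with 4-hydroxyphenyl on this aromatic carbon, the shared core gives a readable number in this assay, where compound 4 stands at 162000 nM, so the size of a change at this place can be bounded for the first time. The earlier step between two limits cannot be read. Replacing piperidin-4-yl gives an at least 6.1-fold lower number from compound 2 to compound 4 (0.79 log units; beyond the scatter), and replacing pyrrolidin-2-yl gives an at least 6.1-fold lower number from compound 1 to compound 4 (0.79 log units; beyond the scatter), and the real sizes of both steps may be larger. Piperidin-4-yl and pyrrolidin-2-yl themselves still cannot be told apart, as the readings at this place sit at one edge: the limit of > 1000000 nM in this assay, at which 3 of the 4 values shown sit.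

The compounds shown do not separate the contribution of the aromatic ring from that of its hydroxyl, which plain phenyl and 4-methoxyphenyl at the same place could help to do. They also leave open how a carboxylic acid or an amine in place of that hydroxyl would read in this assay, and whether any group here can bring the number much lower.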